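Acetamido in Place of Bromo: What to Expect

This account rests on a few compounds, and the source may have more. Where it says the series, first, only, none or still open, it means among the compounds named here.

Of the compounds shown here, three built on the same sulfonamide core have been tested in a functional assay on J774 cells (Mus musculus) for cytotoxicity, read by resazurin assay, with a stated time of 72 h; on this read-out lower numbers stand for stronger inhibition and higher numbers for weaker inhibition. Compound 1 `O=S(=O)(Nc1cccc(CO)c1O)c1ccc(-c2ccc(Br)cc2)cc1` gives only a limit in this assay, > 5000 nM, the edge of what the test reports rather than a number. Compound 2 `O=S(=O)(Nc1cccc(CO)c1)c1ccc(-c2ccc(Br)cc2)cc1` gives 2500 nM in this assay, the highest of the two numbers shown. Compound 3 `O=S(=O)(Nc1cccc(CO)c1)c1ccc(-c2ccc(Cl)cc2F)cc1` gives 700 nM in this assay. Hydrogen in place of hydroxy on an aromatic carbon brought an at least 2.0-fold lower number from compound 1 to compound 2 (0.30 log units; that floor lies within the scatter). Exchanging 4-chloro-2-fluorophenyl for 4-bromophenyl on an aromatic carbon brought a 3.6-fold lower number from compound 2 to compound 3 (0.55 log units; beyond the scatter).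

Compound 4 `CC(=O)Nc1ccc(-c2ccc(S(=O)(=O)Nc3cccc(CO)c3)cc2)cc1` differs from compound 2 by acetamido in place of bromo on an aromatic carbon. Neither measured step matches this change directly; the step from compound 2 to compound 3 only shows that altering the group at that place can move the number modestly. Compound 4 is therefore expected to show a 1.2-fold higher number from compound 2 to compound 4 (0.08 log units; within the scatter), a step that need not exceed the scatter. The estimate for compound 4 is 3000 nM, with a range from 1000 nM to 9000 nM.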

Compound 4, half-maximal inhibitory concentration: > 5000 nM
Compound 4: a limit, no number; the forecaster's own chance of this, stated with the estimate: 30%; middle value at least 1.6-fold (0.22 log units) from the limit.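

Putting acetamido in place of bromo gave an at least 2.0-fold higher number from compound 2 to compound 4 (0.30 log units; that floor lies within the scatter) in this assay. Among the compounds shown here, compound 3 showed only that a change at this end of the molecule can lower the number, whereas this swap of a single bromine atom for a four-atom group with a carbonyl and an amide hydrogen gives the first sign that a change here can raise it. Compound 4 gives only a limit, so the true size of the step cannot be read, and the floor alone does not clear the usual scatter: the limit of > 5000 nM in this assay, at which 2 of the 4 values shown sit.

The compounds shown leave open whether the amide hydrogen or the carbonyl matters more, which a plain amine or a methyl ester at the same place could help separate. They also leave open how a carboxylic acid or a longer chain such as propionamido would read here.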